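Amide replacement on the shared core: cytotoxicity outlook

A few compounds are considered here, and "the series" means these few. Any claim that something is new, unique, unknown or untested is made for them only; others in the source may bear on it.

Compound 1 `Cn1c(-c2cccc([N+](=O)[O-])c2)cnc1NC(=O)c1ccc(F)cc1`, compound 3 `Cc1cccc(-c2cnc(NC(=O)c3ccc(F)cc3)n2C)c1` and compound 2 `COc1ccc(-c2cnc(NC(=O)C3CCOCC3)n2C)cc1` share one core and differ in the aryl group and in the amide. In a toxicity assay on THP-1 cells (Homo sapiens) for inhibition (on this read-out lower numbers stand for higher toxicity in this test and higher numbers for lower toxicity in this test), compound 1 gives only a limit, > 50000 nM. In this assay compound 3 gives only a limit, > 100000 nM. Compound 2 also gives only a limit in this assay, > 100000 nM, so no number places it among the others. The step that the two limits leave unreadable from compound 1 to compound 3 is unreadable. Compound 4 `COc1ccc(-c2cnc(NC(=O)c3ccccc3O)n2C)cc1` differs from compound 2 by 2-hydroxyphenyl in place of oxan-4-yl on a carbonyl carbon. Among the measured compounds shown here, no measured step touches the amide; the only guide is the limit of > 100000 nM in this assay, at which 2 of the 3 values shown sit, together with the limit of > 50000 nM in this assay, at which 1 of the 3 values shown sits. Compound 4 is therefore expected to sit near the limit, with the step of a number no higher from compound 2 to compound 4 (the limit leaves the size open) expected to be none beyond the scatter. The estimate for compound 4 is 100000 nM, between 30000 nM and 300000 nM.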

Compound 4, half-maximal cytotoxic concentration: > 100000 nM
Compound 4 gave a limit, no number (the forecaster's own chance of this, stated with the estimate: 85%); the middle value sits exactly at the limit.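

Among the compounds shown here, compound 2 and compound 4 both stand only as limits, so no step between them can be read. The compounds shown leave open whether 2-hydroxyphenyl in place of oxan-4-yl on a carbonyl carbon changes toxicity at all.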